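Replacing 1,3-thiazol-2-yl with pyrimidin-5-yl

This account rests on a few compounds, and the source may have more. Where it says the series, first, only, none or still open, it means among the compounds named here.

Compound 1 `CCn1nc(-c2cccnc2)c2ccccc2c1=O` gives 1320 nM
Compound 2 `COC(=O)c1ccc(Cn2nc(-c3cccnc3)c3ccccc3c2=O)cc1` gives 5890 nM
Compound 3 `CCn1nc(-c2nccs2)c2ccccc2c1=O` gives 3160 nM

All three numbers come from a functional assay (trachea) with Cavia porcellus as the target (on this read-out higher numbers stand for weaker inhibition and lower numbers for stronger inhibition), and are read the same way. Compound 3 lies within the scatter of compound 2. For the measured compounds named here, the only measured step at the changing group shows a 2.4-fold higher number from compound 1 to compound 3 (0.38 log units; beyond the scatter) and is modest in size.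

Compound 4 `CCn1nc(-c2cncnc2)c2ccccc2c1=O` is the next case, with pyrimidin-5-yl in place of 1,3-thiazol-2-yl on an aromatic carbon. Going by the values given here, no measured compound yet carries pyrimidin-5-yl, so that single modest step is the only guide. It suggests a small change at most, perhaps toward compound 1 with 1320 nM, whose pyridin-3-yl is also a six-membered aromatic ring. The expected result is a 1.3-fold lower number from compound 3 to compound 4 (0.12 log units; within the scatter), a slightly lower number that stays within the scatter. For compound 4 the estimate is 2400 nM, with an expected range from 900 nM to 6500 nM.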

Compound 4, half-maximal inhibitory concentration: 9550 nM
Compound 4: the middle estimate sits 4.0-fold (0.60 log units) below what was measured; the whole stated range lies below it.
By their numbers in this assay, from the lowest: compound 1; then compounds 3, 2 and 4 (each within the scatter of the next, the first and the last beyond it).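

Pyrimidin-5-yl does not behave like pyridin-3-yl at this position: in this assay the change gives a 7.2-fold higher number from compound 1 to compound 4 (0.86 log units; beyond the scatter) and is larger than the swap from 1,3-thiazol-2-yl, which gives a 3.0-fold higher number from compound 3 to compound 4 (0.48 log units; beyond the scatter) in the same assay. Among the three compounds that keep the ethyl group and differ only here, the two six-membered aromatic rings lie at opposite ends, with the five-membered 1,3-thiazol-2-yl between them, so ring size alone does not set the number. Nothing available accounts for this difference.

The compounds shown leave open how a plain phenyl ring, with no ring nitrogen, or an amine would fare at this position. On these data alone, it also remains open whether the same order would hold with the group of compound 2 in place of the ethyl group, as only pyridin-3-yl appears with it here.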